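The source may hold more compounds than are shown below. What is called first, only, known or untested is meant among the compounds shown, and "the series" means these compounds.

Compound 1, `COc1cc(C(=O)N/N=C/c2ccc(F)c(F)c2)cc(OC)c1OC`, in a functional assay on PC-3 cells (Homo sapiens) for antiproliferative activity, read by MTT assay, tested at 1 uM; a higher number here means a stronger effect of the compound at the concentration tested, a lower number a weaker effect: 35.1%
Compound 2, `COc1cc(C2=NN(C(C)=O)C(c3c(Cl)cccc3Cl)O2)cc(OC)c1OC`, in this assay: 5.1%
Compound 3, `COc1cc(C(=O)N/N=C/c2ccccc2C(F)(F)F)cc(OC)c1OC`, in this assay: 45%

Compound 2 stands lowest of the three numbers in this assay. Its nearest neighbour is compound 1, whose number lies higher by a margin beyond the scatter, and compound 3 lies further above it, also beyond the scatter. Both of those carry a different core from compound 2, so neither gives a step that isolates a single change on the core of compound 2.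

Compound 4, `COc1cc(C2=NN(C(C)=O)C(c3cccc(OC)c3OC)O2)cc(OC)c1OC`, has not yet been measured. It differs from compound 2 in one place: 2,3-dimethoxyphenyl in place of 2,6-dichlorophenyl on a saturated ring carbon. No pair of measured compounds shows this change, so there is nothing in the shown data from which to size it directly, and the only anchor is the low number of compound 2 itself.

Compound 4 is expected to give 12% in this assay, within a range from 0% to 35%. The step of a number 6.9 percentage points higher from compound 2 to compound 4 (within the scatter) is expected to be small, if anything upward, and not clearly beyond the scatter.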

Compound 4, a percentage reported as inhibition, at one concentration (the size of the read-out at that concentration, not a potency): 35%
Beside the measured number, compound 4's estimate is 23 percentage points below it, within the range that was stated.
By their numbers in this assay, from the lowest: compound 2; then compounds 4, 1 and 3 (each within the scatter of the next).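

On the saturated ring carbon of the shared core, 2,3-dimethoxyphenyl in place of 2,6-dichlorophenyl gives a number 29.9 percentage points higher from compound 2 to compound 4 (beyond the scatter) in this assay. Within the data shown here, this is the first single change that can be read, and it shows that the aryl group at this position can by itself alter the effect at the concentration tested, which the earlier compounds, with their different cores, could not show. Nothing in the data shown accounts for this step.

With one step, the loss of the two chlorine atoms cannot be separated from the gain of the two methoxy groups. Also open, going by these compounds, is how the number would respond to a phenyl ring carrying an amine or a carboxylic acid at this carbon, or to another group in place of the acetyl group.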